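Adding chlorine to compound 2 in the electroshock model

This account rests on a few compounds, and the source may have more. Where it says the series, first, only, none or still open, it means among the compounds named here.

In a functional assay on the whole organism with Mus musculus as the target, in the maximal electroshock model (a lower number here means that less compound is needed, a higher number that more compound is needed for the effect), compound 1 `Cc1nn2cnnc2cc1Cc1ccccc1Cl` gives 6 mg/kg. Compound 2 `Cc1nn2c(C)nnc2cc1Cc1ccccc1` gives 26 mg/kg in this assay, the highest of the two numbers; compound 1 lies a good deal lower, beyond the scatter. Compound 3 `Cc1nn2c(C)nnc2cc1Cc1ccccc1Cl` is compound 2 with chloro in place of hydrogen on an aromatic carbon, placed ortho to a large group on the six-membered aromatic ring of carbon only. Among the compounds with values here, no measured pair shows this change alone, but since compound 1 carries the same chloro group and gives 6 mg/kg, a step toward a lower dose beyond the scatter is expected; compound 3 is estimated at 10 mg/kg, between 4 mg/kg and 25 mg/kg, a change of a 2.6-fold lower number from compound 2 to compound 3 (0.41 log units; beyond the scatter).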

Compound 3, dose for half-maximal effect: 30.5 mg/kg
Estimate against measurement, compound 3: 3.1-fold (0.48 log units) below; the measured number lies above the stated range.
By their numbers in this assay, from the lowest: compound 1; then compounds 2 and 3 (each within the scatter of the next).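

In this assay chloro in place of hydrogen on an aromatic carbon, ortho to a large group, amounts to a 1.2-fold higher number from compound 2 to compound 3 (0.07 log units; within the scatter) and so does not carry the number toward a lower dose here. Adding the methyl group, with the chloro group present, amounts to a 5.1-fold higher number from compound 1 to compound 3 (0.71 log units; beyond the scatter) and is the one step here beyond the scatter. Nothing measured accounts for this. On these data alone, whether fluoro, methoxy or an amine at this place would behave as chloro does remains open, as does whether the methyl step holds on a ring without chloro.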